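Swapping trifluoromethyl for chloro on a non-cytotoxic scaffold

This account rests on a few compounds, and the source may have more. Where it says the series, first, only, none or still open, it means among the compounds named here.

Compound 2 `Cc1ccc(S(=O)(=O)Cc2nc(Nc3cccc(C(F)(F)F)c3)c3cc([N+](=O)[O-])ccc3n2)cc1` is one of the two compounds examined in an ADME assay on HepG2 cells (Homo sapiens) for cytotoxicity, read by MTT assay, with a stated time of 72 h; on this read-out higher numbers stand for weaker inhibition and lower numbers for stronger inhibition. In this assay compound 2 gives > 100000 nM, which is a limit of the assay rather than a number. Compound 1 `CC(C)=Cc1nc(Nc2cccc(C(F)(F)F)c2)c2cc([N+](=O)[O-])ccc2n1` shares the same core; in this assay compound 1 gives > 100000 nM, again a limit. Going by the values given here, the only step measured, a step that the two limits leave unreadable from compound 1 to compound 2, thus has no readable size. Among the compounds with values here, the sole evidence on hand is the limit of > 100000 nM in this assay, at which 2 of the 2 values shown sit.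

Compound 3 `Cc1ccc(S(=O)(=O)Cc2nc(Nc3cccc(Cl)c3)c3cc([N+](=O)[O-])ccc3n2)cc1` differs from compound 2 by chloro in place of trifluoromethyl on an aromatic carbon. Within the data shown here, no measured step bears directly on this change: the single measured step concerns a different part of the molecule and its size cannot be read. With both measured compounds sitting at the limit, compound 3 is expected to behave in the same way and to show no measurable inhibition in this assay. The step that the limit leaves unreadable from compound 2 to compound 3 is therefore estimated to be none beyond the scatter. Compound 3 is estimated at 150000 nM, with a range from 50000 nM to 500000 nM.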

Compound 3, half-maximal inhibitory concentration: > 100000 nM
Compound 3 was reported as a limit (the forecaster's own chance of this, stated with the estimate: 85%); the middle value lies beyond the limit too.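

In this assay, going by these compounds alone, compound 3 gives > 100000 nM, which is a limit and not a number, so no step from compound 2 to compound 3 can be read. The compounds shown leave open how far any of them lies from that limit, and whether chloro in place of trifluoromethyl changes the read-out at all: the limit of > 100000 nM in this assay, at which 3 of the 3 values shown sit.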